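Methoxy in Place of Methyl: From Compound 2 to Compound 4

The compounds below may be only part of what the source reports. "The series", "measured", "known", "first", "only" and "open" are said of these compounds alone.

Of the compounds shown here, three have been measured. Compound 1 `Cc1cccc(NC(=O)N[C@H](C)c2ccccc2)c1`, compound 2 `Cc1cccc(NC(=O)N[C@@H](C)c2ccccc2)c1` and compound 3 `CCCCc1ccc(NC(=O)N[C@@H](C)c2ccccc2)cc1` share one core. In an ADME assay on the whole organism with Oryza sativa as the target, tested at 0.1 uM (a higher number here means a weaker effect of the compound at the concentration tested, a lower number a stronger effect), compound 1 gives 100%, compound 2 gives 99% and compound 3 gives 98%. Going by the values given here, the only single-change step among them is a number 1 percentage points lower from compound 1 to compound 2 (within the scatter), which fits (the fact that compounds 1 and 2 differ only in the configuration as drawn). Compound 2 stands second highest of the three numbers, within the scatter of compound 1 above it and of compound 3 below it.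

Compound 4 `COc1cccc(NC(=O)N[C@@H](C)c2ccccc2)c1` has not been measured. It differs from compound 2 in one place: methoxy in place of methyl on an aromatic carbon. Among the compounds with values here, no measured step exchanges one substituent for another on the ring, so none bears directly on this change; all three measured values lie within the scatter of one another. The step of a number 1 percentage points lower from compound 2 to compound 4 (within the scatter) is therefore expected to stay within the scatter, with no direction. Compound 4 is estimated at 98%, in a range from 88% to 100%.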

Compound 4, a percentage reported as activity, at one concentration (the size of the read-out at that concentration, not a potency): 101%
Estimate against measurement, compound 4: 3 percentage points below; measured number outside the range, above it.
By their numbers in this assay, from the lowest: compounds 3, 2, 1 and 4 (each within the scatter of the next).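

In this assay, methoxy in place of methyl on an aromatic carbon, meta to a large group, gives a number 2 percentage points higher from compound 2 to compound 4 (within the scatter). Going by these compounds alone, this is the first single-change step in these compounds that alters a substituent on the ring rather than the configuration as drawn, and it shows that this position accepts the methoxy oxygen, with its hydrogen-bond acceptor, with no change in the read-out beyond the scatter. Nothing known about these compounds bears on why this exchange behaves as it does.

The compounds shown leave open whether any group on this carbon, such as an amine or a carboxylic acid, would move the number beyond the scatter. They also leave open whether the exchange of methyl for methoxy would behave the same way with the configuration drawn in compound 1.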